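Swapping the sulfonamide heteroaryl of a chromone aminomethyl series

The source may hold more compounds than are shown below. What is called first, only, known or untested is meant among the compounds shown, and "the series" means these compounds.

Three chromone-bearing sulfonamides have been examined in a functional assay on A549 cells (Homo sapiens) for cytotoxicity, read by sulforhodamine B assay, with a stated time of 72 h; on this read-out higher numbers stand for weaker inhibition and lower numbers for stronger inhibition. Compound 1, `Cc1cc(C)nc(NS(=O)(=O)c2ccc(NCc3coc4ccccc4c3=O)cc2)n1`, gives 55800 nM in this assay. Compound 2, `O=C1/C(=C/c2coc3ccccc3c2=O)N=C(c2ccccc2)N1c1ccc(S(=O)(=O)Nc2ncccn2)cc1`, gives 40500 nM in this assay, and compound 3, `CCOC1Oc2ccccc2C(=O)/C1=C/Nc1ccc(S(=O)(=O)Nc2cc(C)on2)cc1`, gives 57200 nM in this assay. Among these three numbers compound 1 stands second highest, yet its distance to compound 3 and its distance to compound 2 both fall within the usual scatter of repeated measurements, so the three cannot be told apart on this evidence.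

The account now moves from compound 1 to compound 4, `Cc1cc(NS(=O)(=O)c2ccc(NCc3coc4ccccc4c3=O)cc2)no1`, which has not yet been measured in this assay. The change is 5-methyl-1,2-oxazol-3-yl in place of 4,6-dimethylpyrimidin-2-yl on a sulfonamide nitrogen. For the measured compounds named here, no pair of measured compounds differing in one place is available to calibrate this swap. The closest guide is compound 3, which also carries a 5-methyl-1,2-oxazol-3-yl on its sulfonamide nitrogen and gives 57200 nM in this assay, a number within the scatter of compound 1.

On that basis the step is expected to be none beyond the scatter: the estimated move a 1.0-fold lower number from compound 1 to compound 4 (0.01 log units; within the scatter) is essentially flat. Compound 4 is therefore expected to give about 55000 nM in this assay, with a likely range from 25000 nM to 120000 nM.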

Compound 4, half-maximal inhibitory concentration: 59700 nM
For compound 4 the middle estimate is 1.1-fold (0.04 log units) below the measured one, and the stated range covers the measured number.
By their numbers in this assay, from the lowest: compounds 2, 1, 3 and 4 (each within the scatter of the next).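

For the compounds shown here, the step from the 4,6-dimethylpyrimidin-2-yl group to the 5-methyl-1,2-oxazol-3-yl group on the sulfonamide nitrogen gives the first direct one-place reading at this position: in this assay the change is a 1.1-fold higher number from compound 1 to compound 4 (0.03 log units; within the scatter) and so cannot be told from repeat-measurement noise. The earlier compounds shown here could not show this, since each differed from the others in more than one place. Here, a five-membered aromatic ring with fewer heavy atoms replaces a six-membered one on an otherwise unchanged core, with the counted hydrogen-bond donors and acceptors the same, and the read-out stays flat. No measured property of either group accompanies this result, so the data offer no explanation for the flat step.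

What the compounds shown leave open is whether any group on this sulfonamide nitrogen can move the number beyond the scatter, as the single step here stays within it. A plain phenyl ring, a simple acetyl group or a pyridine ring bearing a carboxylic acid in place of these two heteroaryl groups would test how far this flat behaviour extends.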